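Extending a methylamide toward a methoxyethyl chain

The compounds below may be only part of what the source reports. "The series", "measured", "known", "first", "only" and "open" are said of these compounds alone.

Three compounds have been measured in a physicochemical assay for lipophilicity, at pH 7.4; a higher number here means a more lipophilic compound, a lower number a more polar compound:

Compound 1 `CNC(=O)c1cc(C(=O)NC)c(=O)n(Cc2ccccc2)c1` gives 2.4.
Compound 2 `CNC(=O)c1ccc(=O)n(Cc2ccccc2)c1` gives 1.6.
Compound 3 `CNC(=O)c1cc(C(=O)NC2CC2)cn(Cc2cccc3[nH]ncc23)c1=O` gives 1.5.

Compound 1 stands highest of these three numbers in this assay. Its nearest neighbour is compound 2, reached by a single change: a number 0.80 log units lower from compound 1 to compound 2 (beyond the scatter). Among the measured compounds shown here, compound 3 lies further away still, and no single step links it to compound 1, so only the two values can be compared.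

Compound 4 `CNC(=O)c1cc(C(=O)NCCOC)cn(Cc2ccccc2)c1=O` has not yet been measured. It differs from compound 1 in one place: methoxymethyl in place of hydrogen on a saturated chain carbon bound to an amide-type nitrogen. For the measured compounds named here, none of the measured steps bears on this kind of change; the only measured step concerns a methylcarbamoyl group leaving an aromatic carbon, which is a different change from lengthening the chain on an amide-type nitrogen. Going by the values given here, with no comparable step in hand, the expectation for compound 4 is a step of no clear size beyond the scatter, a number 0.10 log units lower from compound 1 to compound 4 (within the scatter), leaning slightly downward. The estimate for compound 4 in this assay is therefore 2.3, within a range from 1.9 to 2.7.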

Compound 4, distribution coefficient: 2.7
Beside the measured number, compound 4's estimate is 0.40 log units below it, within the range that was stated.
By their numbers in this assay, from the lowest: compounds 3 and 2 (each within the scatter of the next); then compounds 1 and 4 (each within the scatter of the next).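

Among the compounds shown here, until now, no measured step touched a saturated chain carbon bound to an amide-type nitrogen. Here, turning methylcarbamoyl into (2-methoxyethyl)carbamoyl gives a number 0.30 log units higher from compound 1 to compound 4 (within the scatter) in this assay, so adding methoxymethyl, with its 3 heavy atoms, gives a value that cannot be told apart from that of compound 1, whereas removing a whole methylcarbamoyl group gave a number 0.80 log units lower from compound 1 to compound 2 (beyond the scatter) as a step beyond the scatter. No measurement at hand explains why the added chain leaves the value so close.

The compounds shown leave open whether a longer chain, or an amine or a carboxylic acid at the end of this chain, would also stay within the scatter. They also leave open whether the same change on the other methylcarbamoyl group of compound 1 would read alike.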